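Trading a pyridyl ester for a dimethylamide on the oxazole

The source may report more compounds than this note shows. Statements on the series, on what has been measured and on what is new or still open speak of the compounds shown alone.

Measured so far in an assay for inhibition of Fatty-acid amide hydrolase 1 (Rattus norvegicus); on this read-out lower numbers stand for stronger inhibition and higher numbers for weaker inhibition:
compound 1 `COC(=O)c1cc(-c2cnc(C(=O)CCc3ccc(-c4ccccc4)cc3)o2)ccn1`: 1.5 nM
compound 2 `NC(=O)c1cccc(-c2cnc(C(O)CCc3ccc(-c4ccccc4)cc3)o2)n1`: 20000 nM
compound 3 `NC(=O)c1ccc(-c2cnc(C(O)CCc3ccc(-c4ccccc4)cc3)o2)nc1`: limit, > 1000 nM

Compound 1 is the lowest of the two numbers shown; compound 2 sits far higher, beyond the scatter. Compound 3 gives only a limit, (the limit of > 1000 nM in this assay, at which 1 of the 3 values shown sits), so the step that the limit leaves unreadable from compound 2 to compound 3 cannot be sized. Neither of these two compounds differs from compound 1 in one place alone, so their values say nothing directly about the change now at hand.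

Compound 4 `CN(C)C(=O)c1cnc(C(=O)CCc2ccc(-c3ccccc3)cc2)o1` keeps the core of compound 1 and changes it at one spot: dimethylcarbamoyl in place of 2-(methoxycarbonyl)pyridin-4-yl on an aromatic carbon. Among the measured compounds shown here, no measured step covers this change. A large aromatic group with three acceptors is removed and a small non-ring group with one acceptor takes its place; such a loss of a sizable piece is expected to cost some inhibition, so the step of a 20-fold higher number from compound 1 to compound 4 (1.30 log units; beyond the scatter) is expected to run toward weaker binding. Compound 4 is therefore estimated at 30 nM, within 5 nM to 200 nM.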

Compound 4, inhibition constant: 3 nM
The estimate for compound 4 lay 10-fold (1.00 log units) above the measured number; measured number outside the range, below it.
By their numbers in this assay, from the lowest: compounds 1 and 4 (each within the scatter of the next); then compound 2.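

In this assay, placing dimethylcarbamoyl where 2-(methoxycarbonyl)pyridin-4-yl stood gives a 2.0-fold higher number from compound 1 to compound 4 (0.30 log units; within the scatter). Among the compounds shown here, this is the first direct reading at this aromatic carbon next to the ring oxygen, and it shows that a pyridine ring and its ester are not required here for a low number: a smaller group with no ring serves within the scatter. No measurement shown here explains why the two groups give such close values.

On these data alone, it remains open how far this position tolerates other groups, such as a carboxylic acid, a methyl ester attached directly to the ring, or a simple amine. As far as these compounds go, whether the two methyl groups of the amide matter also remains open, since a diethylamide or a morpholine amide would be needed to test that.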